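This account rests on a few compounds, and the source may have more. Where it says the series, first, only, none or still open, it means among the compounds named here.

Measured so far:
- compound 1 `CN(C)c1ccc(C2CC(c3ccccc3)=NN2C2=NC(=O)/C(=C3\C(=O)Nc4ccccc43)S2)cc1`: in a functional assay on cells (Cancer cell lines, Homo sapiens) for cytotoxicity, read by sulforhodamine B assay, with a stated time of 48 h (a lower number here means a stronger inhibitor of growth, a higher number a weaker inhibitor of growth), compound 1 gives 6370 nM
- compound 2 `CN(C)c1ccc(C2CC(c3ccccc3)=NN2C2=NC(=O)/C(=C3\C(=O)Nc4ccc(Br)cc43)S2)cc1`: in this assay compound 2 gives 200 nM

Among the measured compounds shown here, compound 2 gives the lower of the two numbers; the only step known, a 32-fold lower number from compound 1 to compound 2 (1.50 log units; beyond the scatter), shows how far apart the two stand. That step was a large one, and it came from adding bromo to a hydrogen position on the shared core.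

Compound 3 `CN(C)c1ccc(C2CC(c3ccccc3)=NN2C2=NC(=O)/C(=C3\C(=O)Nc4ccc(Cl)cc43)S2)cc1` differs from compound 2 by chloro in place of bromo on an aromatic carbon. For the measured compounds named here, no measured step tells how the chloro compares with the bromo at this position; the one step at hand, a 32-fold lower number from compound 1 to compound 2 (1.50 log units; beyond the scatter), only shows that a halogen at that place gave a far lower number than hydrogen. Since chloro is the nearer neighbour of bromo, the number for compound 3 is expected to stay close to that of compound 2, with a modest upward step a 1.5-fold higher number from compound 2 to compound 3 (0.18 log units; within the scatter) allowed for. Compound 3 is therefore estimated at 300 nM in this assay, within a range of 120 nM to 900 nM.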

Compound 3, concentration for 50% growth inhibition: 190 nM
Estimate against measurement, compound 3: 1.6-fold (0.20 log units) above; the measured number falls inside the stated range.
By their numbers in this assay, from the lowest: compounds 3 and 2 (each within the scatter of the next); then compound 1.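

In this assay, chloro and bromo on this aromatic carbon cannot be told apart: the change is a 1.1-fold lower number from compound 2 to compound 3 (0.02 log units; within the scatter). The large gain seen earlier therefore does not belong to bromo alone, since putting chloro in place of hydrogen gives a 34-fold lower number from compound 1 to compound 3 (1.53 log units; beyond the scatter), so two different halogens at this place both stand far from the hydrogen compound. Nothing at hand explains why either halogen has this effect.

The compounds shown leave open whether fluoro or iodo would behave like chloro and bromo here, and whether a group with no halogen at all, such as methyl, methoxy or an amine, would also hold the number down. They also leave open whether chloro on another carbon of the same ring would give a similar result.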